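Lengthening the chain between amide and indole

A few compounds are considered here, and "the series" means these few. Any claim that something is new, unique, unknown or untested is made for them only; others in the source may bear on it.

Three measured compounds share one core and differ only in how the indole is joined to the amide carbonyl. Compound 1 `COc1ccccc1N1CCN(CCCNC(=O)c2ccc3[nH]ccc3c2)CC1` gives 26.3 nM in an assay on isolated protein (Vas deferens, strain Sprague-Dawley) for antagonist activity at Alpha-1A adrenergic receptor (Rattus norvegicus), with a stated time of 20 min; on this read-out lower numbers stand for tighter binding and higher numbers for weaker binding. Compound 2 `COc1ccccc1N1CCN(CCCNC(=O)Cc2c[nH]c3ccccc23)CC1` gives 7.94 nM in this assay, and the step of a 3.3-fold lower number from compound 1 to compound 2 (0.52 log units; beyond the scatter) is a modest gain in binding. Compound 3 `COc1ccccc1N1CCN(CCCNC(=O)CCc2c[nH]c3ccccc23)CC1` gives 195 nM in this assay, and the step of a 25-fold higher number from compound 2 to compound 3 (1.39 log units; beyond the scatter) is a large loss. Compound 3 thus stands at the highest number of the three, well apart from compound 1 and furthest from compound 2, so it is the weakest binder measured so far.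

Compound 4 `COc1ccccc1N1CCN(CCCNC(=O)CCCc2c[nH]c3ccccc23)CC1` has not yet been measured. It differs from compound 3 by (1H-indol-3-yl)methyl in place of 1H-indol-3-yl on a saturated chain carbon, two bonds along the chain from a carbonyl carbon, that is, one more saturated carbon in the chain between the carbonyl and the indole. The step that bears on this is a 25-fold higher number from compound 2 to compound 3 (1.39 log units; beyond the scatter), where the same kind of lengthening by one carbon produced a large rise in the number. The earlier step of a 3.3-fold lower number from compound 1 to compound 2 (0.52 log units; beyond the scatter) changed the attachment point on the indole as well, so it speaks less directly. A further rise in this assay is therefore expected, though the size is uncertain. Compound 4 is expected at about 400 nM, within 100 nM to 1600 nM, which means a step of a 2.1-fold higher number from compound 3 to compound 4 (0.31 log units; beyond the scatter) from compound 3.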

Compound 4, dissociation constant: 12.6 nM
For compound 4 the middle estimate is 32-fold (1.50 log units) above the measured one; measured number below the stated range.
By their numbers in this assay, from the lowest: compounds 2 and 4 (each within the scatter of the next); then compound 1; then compound 3.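

In this assay, binding does not simply fall as the chain carrying the indole grows: the one-carbon lengthening in a 25-fold higher number from compound 2 to compound 3 (1.39 log units; beyond the scatter) is followed by a further one-carbon lengthening that gives a 15-fold lower number from compound 3 to compound 4 (1.19 log units; beyond the scatter). The effect of one added carbon therefore depends on the chain it joins, and the direction of one step could not be carried over to the next, while compound 2 and compound 4 lie within the scatter of each other and compound 3 stands apart from both with the higher number. Nothing measured here says why the direction reverses.

From the compounds shown here alone, it remains open whether this recovery lasts, since a longer chain with one more saturated carbon could hold the number low or send it up again. Going by these compounds, it is also open whether the same pattern holds with 1H-indol-5-yl on the longer chains, or with an amine in place of the amide carbonyl, so chain length on its own is not yet separated from these other features.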